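The compounds below may be only part of what the source reports. "The series", "measured", "known", "first", "only" and "open" are said of these compounds alone.

Measured compounds in a functional assay on U-87MG ATCC cells for inhibition, with U-87 MG (Homo sapiens) as the target, read by MTT assay, with a stated time of 72 h; on this read-out higher numbers stand for weaker inhibition and lower numbers for stronger inhibition:
- compound 1 `Cc1noc(C)c1-c1cnc(N)c(Oc2ccc(C(=O)NC3CC3)cc2)n1`: 43300 nM
- compound 2 `Cc1noc(C)c1-c1cnc(N)c(Oc2ccc(C(=O)Nc3ccccc3)cc2)n1`: 26600 nM

Compound 1 stands alongside compound 2 on these two numbers: the step of a 1.6-fold lower number from compound 1 to compound 2 (0.21 log units; within the scatter) lies within the scatter, so the two are not separated by this assay. Compound 3 `Cc1noc(C)c1-c1cnc(N)c(Oc2ccc(C(=O)Nc3ccc(Cl)cc3)cc2)n1` is the unmeasured member. It differs from compound 1 by 4-chlorophenyl in place of cyclopropyl on an amide-type nitrogen.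

Going by the values given here, the only measured step that bears on this change is a 1.6-fold lower number from compound 1 to compound 2 (0.21 log units; within the scatter), which exchanges the same cyclopropyl for a plain phenyl on the same amide-type nitrogen and stays within the scatter. Among the compounds with values here, no measured pair shows what the chlorine on the phenyl adds, so that part of the change has no precedent. On the evidence of compound 2 and its value 26600 nM, a number near that of compound 2, or somewhat lower, is expected for compound 3, giving an expected step of a 2.2-fold lower number from compound 1 to compound 3 (0.34 log units; beyond the scatter). The estimate for compound 3 in this assay is 20000 nM, with a range from 7000 nM to 50000 nM.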

Compound 3, half-maximal inhibitory concentration: 15500 nM
The estimate for compound 3 lay 1.3-fold (0.11 log units) above the measured number, and the stated range covers the measured number.
By their numbers in this assay, from the lowest: compounds 3, 2 and 1 (each within the scatter of the next, the first and the last beyond it).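

In this assay, the change on the amide-type nitrogen now gives a step beyond the scatter: a 2.8-fold lower number from compound 1 to compound 3 (0.45 log units; beyond the scatter), a modest step, whereas the plain phenyl in a 1.6-fold lower number from compound 1 to compound 2 (0.21 log units; within the scatter) did not separate from cyclopropyl. Going by these compounds alone, the chloro in place of hydrogen on an aromatic carbon, seen by itself for the first time in a 1.7-fold lower number from compound 2 to compound 3 (0.23 log units; within the scatter), stays within the scatter, so compound 2 and compound 3 are not separated by this measurement, and only the full exchange of cyclopropyl for 4-chlorophenyl can be read as a difference. No available evidence accounts for this step.

Open, on these data alone, is whether other groups on the phenyl ring, such as methoxy, an amine or a carboxylic acid, would give a step beyond the scatter from compound 2, and whether a longer alkyl chain on the amide-type nitrogen would differ from cyclopropyl. All three compounds keep the core of compound 1 unchanged, so these notes give no reading of how changes in that core would affect the number.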